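This account rests on a few compounds, and the source may have more. Where it says the series, first, only, none or still open, it means among the compounds named here.

Measured so far:
Compound 1, `CCCCN(CC)c1cc(C)nc2c1NC(=O)CN2c1ccc(C)cc1Br` — 4.4 nM
Compound 2, `CCCCN(CC)c1cc(C)nc2c1NC(=O)CN2c1ccc(Br)cc1C` — 4.4 nM

Both compounds were tested in an assay on HEK-293T cells for displacement of a labelled ligand from corticotropin-releasing factor receptor 1 (Homo sapiens), read by scintillation counting, with a stated time of 2 h; a lower number here means a stronger inhibitor, a higher number a weaker inhibitor. Among the compounds with values here, compound 1 gives 4.4 nM and compound 2 gives 4.4 nM in this assay; the one measured step, no change at the digits printed from compound 1 to compound 2 (within the scatter), shows that swapping the places of the bromo and the methyl on the aryl ring left the number unchanged within the scatter. Compound 2 therefore stands level with compound 1, and neither can be called the stronger of the two.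

Compound 3, `CCCCN(CC)c1cc(C)nc2c1NC(=O)CN2c1ccc(I)cc1C`, is the next candidate. It differs from compound 2 in one place: iodo in place of bromo on an aromatic carbon. Within the data shown here, no measured step here touches a bromo-to-iodo exchange, so the only guide is that the single recorded change on this aryl ring, the step from compound 1 to compound 2, brought no movement beyond the scatter. On that basis, the exchange of one halogen for another at the same aromatic carbon is expected to give little or no shift in this assay, the step of no change at the digits printed from compound 2 to compound 3 (within the scatter) being the estimate. Compound 3 is estimated at 4.4 nM, with a range from 2 nM to 10 nM.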

Compound 3, inhibition constant: 3.4 nM
The estimate for compound 3 lay 1.3-fold (0.11 log units) above the measured number, and the stated range covers the measured number.
By their numbers in this assay, from the lowest: compounds 3, 1 and 2 (each within the scatter of the next).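

In this assay, within the data shown here, the exchange of bromo for iodo on the aromatic carbon para to a large group and meta to a methyl group gives a 1.3-fold lower number from compound 2 to compound 3 (0.11 log units; within the scatter), so here the halogen itself is varied for the first time, rather than only its place on the aryl ring. Comparing the whole aryl groups, 4-iodo-2-methylphenyl in place of 2-bromo-4-methylphenyl gives a 1.3-fold lower number from compound 1 to compound 3 (0.11 log units; within the scatter), which means that changing the halogen and its place together also stays inside the scatter, and all three compounds remain level in this measurement. Nothing measured here accounts for why the number holds across these exchanges.

As far as these compounds go, all three compounds carry a halogen and a methyl group on the aryl ring, so it remains open whether the position that holds bromo or iodo would also accept fluoro, chloro, an amine, a carboxylic acid or a longer chain such as butyl. From the compounds shown here alone, it is equally open how the number would respond if the methyl group on that ring were removed, or if the butyl and ethyl chains on the shared core were replaced.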